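Swapping Trifluoromethoxy for Methyl on a Shared Core

A few compounds are considered here, and "the series" means these few. Any claim that something is new, unique, unknown or untested is made for them only; others in the source may bear on it.

Compound 1 `CC(c1ccc(-c2ccccc2)c(F)c1)c1nnc2n1N=C(c1ccc(OC(F)(F)F)cc1)CS2` is measured in a functional assay on HCT-116 cells (Homo sapiens) for inhibition, read by sulforhodamine B assay, with a stated time of 72 h (a higher number here means a weaker inhibitor, a lower number a stronger inhibitor), where compound 1 gives 5400 nM. Among the three compounds measured so far this is the lowest number, but its neighbours sit close: compound 2 `CC(c1ccc(-c2ccccc2)c(F)c1)c1nnc2n1N=C(c1ccccc1)CS2` gives 9700 nM, and compound 3 `COc1ccc2cc(C(C)c3nnc4n3N=C(c3ccc(C)cc3)CS4)ccc2c1`, which carries a different aromatic group on the other side of the shared core, gives 10200 nM. Both differences from compound 1 lie within the scatter of this assay, so the three compounds cannot be ranked against one another.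

Compound 4 `Cc1ccc(C2=Nn3c(nnc3C(C)c3ccc(-c4ccccc4)c(F)c3)SC2)cc1` has not yet been measured. It differs from compound 1 in one place: methyl in place of trifluoromethoxy on an aromatic carbon.

Within the data shown here, one measured step bears on this change. Going a 1.8-fold higher number from compound 1 to compound 2 (0.25 log units; within the scatter), the trifluoromethoxy group was removed entirely and the number barely moved. Replacing the same group with methyl is a change of similar kind at the same position, so the expectation is that compound 4 will again sit near compound 1, with no step beyond the scatter.

Compound 4 is therefore estimated at 7000 nM in this assay, with a likely range from 3500 nM to 14000 nM, which corresponds to an expected step of a 1.3-fold higher number from compound 1 to compound 4 (0.11 log units; within the scatter).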

Compound 4, half-maximal inhibitory concentration: 4800 nM
The estimate for compound 4 lay 1.5-fold (0.16 log units) above the measured number; the range from low to high includes it.
By their numbers in this assay, from the lowest: compounds 4, 1, 2 and 3 (each within the scatter of the next, the first and the last beyond it).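

In this assay the exchange of trifluoromethoxy for methyl gives a 1.1-fold lower number from compound 1 to compound 4 (0.05 log units; within the scatter) and so, on this aromatic carbon, a group of 5 heavy atoms and a group of 1 heavy atom cannot be told apart. Among these compounds, the new comparison with the unsubstituted ring is more informative: methyl in place of hydrogen gives a 2.0-fold lower number from compound 2 to compound 4 (0.31 log units; beyond the scatter) and is the first step at this position to reach beyond the usual scatter, though only modestly, whereas the earlier removal of trifluoromethoxy gave a 1.8-fold higher number from compound 1 to compound 2 (0.25 log units; within the scatter) and did not. Nothing shown here offers an explanation for these numbers.

Going by these compounds, the groups compared so far on this carbon are only hydrogen, methyl and trifluoromethoxy, so it remains open whether an amine, a carboxylic acid or a longer chain such as butyl would leave the number where it is or move it well beyond the scatter. On these data alone, it also remains open whether methyl in place of hydrogen would give a similar step when the other side of the shared core carries a different aromatic group.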